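The source may report more compounds than this note shows. Statements on the series, on what has been measured and on what is new or still open speak of the compounds shown alone.

Measured in a functional assay on Raji cells (Homo sapiens) for antiproliferative activity, read by MTT assay, with a stated time of 48 h; on this read-out lower numbers stand for stronger inhibition and higher numbers for weaker inhibition:
- Compound 1 `Cn1c(N)c(-c2nc3ccccc3[nH]2)c2nc(C#N)c(C#N)nc21`: > 50000 nM
- Compound 2 `CN1CCN(CCn2c(N)c(-c3nc4ccccc4[nH]3)c3nc(C#N)c(C#N)nc32)CC1`: > 50000 nM

The value of compound 1, > 50000 nM, is a limit of the assay and not a number. The value of compound 2, > 50000 nM, is also a limit. So compound 2 has no exact place on the scale, and its standing comes down to the limit of > 50000 nM in this assay, at which 2 of the 2 values shown sit.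

The next structure is compound 3 `CN1CCN(CCCn2c(N)c(-c3nc4ccccc4[nH]3)c3nc(C#N)c(C#N)nc32)CC1`. It carries (4-methylpiperazin-1-yl)methyl in place of 4-methylpiperazin-1-yl on a saturated chain carbon, two bonds along the chain from an aromatic nitrogen. Put another way, 2-(4-methylpiperazin-1-yl)ethyl becomes 3-(4-methylpiperazin-1-yl)propyl.

For the measured compounds named here, only one measured step bears on this change, a step that the two limits leave unreadable from compound 1 to compound 2. It also concerns the chain on the aromatic nitrogen, but it gives no size to carry forward. No step beyond the usual scatter can therefore be expected in this assay, in either direction, and compound 3 is expected to stay close to the limit that compound 2 reached. The estimated step is a number no higher from compound 2 to compound 3 (the limit leaves the size open). For compound 3 the estimated value is 50000 nM, with an expected range from 20000 nM to 100000 nM.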

Compound 3, half-maximal inhibitory concentration: 2620 nM
For compound 3 the middle estimate is 19-fold (1.28 log units) above the measured one, outside the stated range (below it).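

In this assay, the length of the chain on the aromatic nitrogen matters: replacing 2-(4-methylpiperazin-1-yl)ethyl with 3-(4-methylpiperazin-1-yl)propyl gives an at least 19-fold lower number from compound 2 to compound 3 (1.28 log units; beyond the scatter), the first measurable activity among these compounds. Going by these compounds, the same 3-(4-methylpiperazin-1-yl)propyl chain, set against the chain of compound 1, gives an at least 19-fold lower number from compound 1 to compound 3 (1.28 log units; beyond the scatter), so the gain holds against both earlier compounds, although the true size of each step stays open. The 4-methylpiperazin-1-yl ring alone does not go with this gain, since compound 2 carries it too; the step from compound 1 to compound 2 cannot be read, and both compounds stay at a limit of the assay: the limit of > 50000 nM in this assay, at which 2 of the 3 values shown sit.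

The compounds shown do not tell whether a still longer chain, such as 4-(4-methylpiperazin-1-yl)butyl, would lower the number further or raise it again. They also leave open whether the ring itself is needed on the propyl chain, or whether a morpholine ring or a simple dimethylamino group at its end would do as well.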